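Propargylamine series: from compound 3 to compound 4

The source may report more compounds than this note shows. Statements on the series, on what has been measured and on what is new or still open speak of the compounds shown alone.

Among the measured compounds shown here, compound 1 `C#CCN(C)Cc1cn(-c2cc(NC(=S)NCC)ncn2)cn1` in an assay on isolated protein for inhibition of Amine oxidase [flavin-containing] B (Homo sapiens), read by fluorescence and Amplex Red, with a stated time of 15 min (on this read-out higher numbers stand for weaker inhibition and lower numbers for stronger inhibition), gives 1430 nM and is the only compound with a number rather than a limit. Compound 2 `C#CCN(CCCC)Cc1cn(-c2cc(NC(=S)NCC)ncn2)cn1` reaches only the limit of the method, > 50000 nM. Compound 3 `C#CCN(CC#C)Cc1cn(-c2cc(NC(=S)NCC)ncn2)cn1` likewise sits at the limit, > 50000 nM. Compound 3 therefore stands at the weak end of the shown numbers, since (the limit of > 50000 nM in this assay, at which 2 of the 3 values shown sit). The steps of an at least 34-fold higher number from compound 1 to compound 2 (1.54 log units; beyond the scatter) and an at least 34-fold higher number from compound 1 to compound 3 (1.54 log units; beyond the scatter) are both large, whereas a step that the two limits leave unreadable from compound 2 to compound 3.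

Compound 4 `C#CCNCCCc1cn(-c2cc(NC(=S)NCC)ncn2)cn1` is not yet measured in this assay and differs from compound 3 by 2-(propargylamino)ethyl in place of dipropargylamino on a saturated chain carbon bound to an aromatic carbon. One propargyl on the amine is removed and the chain between amine and core is lengthened. The step of an at least 34-fold higher number from compound 1 to compound 3 (1.54 log units; beyond the scatter) bears on the first part in reverse: taking an ethynyl off the amine substituent is expected to bring the number back down from the limit. For the measured compounds named here, the longer chain has no measured counterpart here. Compound 4 is therefore expected to give 6000 nM, estimated between 900 nM and 40000 nM. This estimate means an expected step of an at least 8.3-fold lower number from compound 3 to compound 4 (0.92 log units; beyond the scatter).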

Compound 4, half-maximal inhibitory concentration: > 50000 nM
Compound 4: no number, only a limit; the forecaster's own chance of this, stated with the estimate: 25%; middle value at least 8.3-fold (0.92 log units) away from the limit.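

In this assay, 2-(propargylamino)ethyl in place of methyl(propargyl)amino on a saturated chain carbon bound to an aromatic carbon gives an at least 34-fold higher number from compound 1 to compound 4 (1.54 log units; beyond the scatter). Among the compounds shown here, compound 1 and compound 4 each carry a single propargyl on the amine, so one propargyl alone does not keep a number on this read-out, and compound 1 remains the only compound with one. The steps from compound 2 and from compound 3 to compound 4 cannot be read, as both ends of each are limits of the assay: the limit of > 50000 nM in this assay, at which 3 of the 4 values shown sit.

Compound 4 differs from compound 1 in both the amine substituent and the chain length, and the shown values do not separate the two changes. Propargylamino on the chain of compound 1, or methyl(propargyl)amino on the longer chain of compound 4, would tell them apart.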